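Swapping the Pyridyl Ketone for a Dimethoxyphenyl Ketone

This account rests on a few compounds, and the source may have more. Where it says the series, first, only, none or still open, it means among the compounds named here.

Measured compounds:
Compound 1 `COc1cc(OC)c(C(=O)/C=C/c2cn(-c3ccccc3)nc2-c2ccsc2)c(OC)c1` gives 2700 nM in a functional assay on MCF7 cells (Homo sapiens) for inhibition, read by sulforhodamine B assay, with a stated time of 72 h; on this read-out higher numbers stand for weaker inhibition and lower numbers for stronger inhibition.
Compound 2 `COc1ccc(C(=O)/C=C/c2cn(-c3ccccc3)nc2-c2ccsc2)c(OC)c1` gives 9000 nM in this assay.
Compound 3 `O=C(/C=C/c1cn(-c2ccccc2)nc1-c1cccnc1)c1ccccn1` gives 4200 nM in this assay.

Among these three numbers compound 3 stands second highest. Its nearest neighbour is compound 1, whose number is lower by an amount within the scatter, so the two cannot be told apart; compound 2 sits further off, with a number higher than that of compound 3 by a margin beyond the scatter.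

Compound 4 `COc1ccc(OC)c(C(=O)/C=C/c2cn(-c3ccccc3)nc2-c2cccnc2)c1` has not yet been measured. It differs from compound 3 in one place: 2,5-dimethoxyphenyl in place of pyridin-2-yl on a carbonyl carbon. For the measured compounds named here, only one measured step speaks to this kind of change, and only loosely: a 3.3-fold higher number from compound 1 to compound 2 (0.52 log units; beyond the scatter), where a methoxy was taken off an aromatic ring on the ketone side. Going by the values given here, no measured pair exchanges a pyridin-2-yl for a dimethoxyphenyl, so the direction of the present step is uncertain. Given that compound 1 and compound 3 lie within the scatter of each other, and that compound 2 is only modestly weaker, compound 4 is expected to land near compound 3, with an estimated step of a 1.1-fold lower number from compound 3 to compound 4 (0.02 log units; within the scatter) that may not exceed the scatter. The estimate for compound 4 in this assay is 4000 nM, within a range from 1500 nM to 11000 nM.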

Compound 4, half-maximal inhibitory concentration: 1500 nM
For compound 4 the middle estimate is 2.7-fold (0.43 log units) above the measured one, and the stated range covers the measured number.
By their numbers in this assay, from the lowest: compounds 4, 1 and 3 (each within the scatter of the next, the first and the last beyond it); then compound 2.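

In this assay the exchange of pyridin-2-yl for 2,5-dimethoxyphenyl on the carbonyl carbon gives a 2.8-fold lower number from compound 3 to compound 4 (0.45 log units; beyond the scatter), so the ring held on this carbonyl carbon can be replaced outright, by a larger carbon-only ring, without any loss of inhibition, and the number in fact drops by a modest margin beyond the scatter. The earlier step, a 3.3-fold higher number from compound 1 to compound 2 (0.52 log units; beyond the scatter), removed only a methoxy from such a ring on a different core, and in both of these pairs the lower number belongs to the compound with more methoxy groups, with neither pair going against this. No measurement shown here gives a reason for the drop in the number.

The exchange removes the ring nitrogen and adds methoxy groups in a single step, so what compound 3 and compound 4 show cannot be divided between those two parts. From the compounds shown here alone, how a plain phenyl, or a phenyl carrying an amine or a longer ethoxy chain, would behave on this carbonyl carbon remains open.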